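The source may hold more compounds than are shown below. What is called first, only, known or untested is meant among the compounds shown, and "the series" means these compounds.

Measured so far in a functional assay for inhibition of sodium/hydrogen exchanger (Oryctolagus cuniculus); a higher number here means a weaker inhibitor, a lower number a stronger inhibitor:
compound 1 `Cc1cc(OCc2ccccc2)c(S(C)(=O)=O)cc1C(=O)N=C(N)N`: 28 nM
compound 2 `Cc1cc(OC2CCCCC2)c(S(C)(=O)=O)cc1C(=O)N=C(N)N`: 37 nM
compound 3 `Cc1cc(-n2cccn2)c(S(C)(=O)=O)cc1C(=O)N=C(N)N`: 25 nM

Compound 3 carries the lowest of the three numbers, but its value and those of compound 1 and compound 2 all lie within the scatter of one another, so no order among them is established. Compound 4 `Cc1cc(Oc2cncc(Cl)c2)c(S(C)(=O)=O)cc1C(=O)N=C(N)N` is not yet measured; it differs from compound 3 as follows: (5-chloropyridin-3-yl)oxy in place of 1H-pyrazol-1-yl on an aromatic carbon. Going by the values given here, two measured steps bear on this exchange, since both end in the group that now leaves: a 1.1-fold lower number from compound 1 to compound 3 (0.05 log units; within the scatter) and a 1.5-fold lower number from compound 2 to compound 3 (0.17 log units; within the scatter). Neither benzyloxy nor cyclohexyloxy differed from 1H-pyrazol-1-yl beyond the scatter in this assay, so compound 4 is expected to show a 1.2-fold higher number from compound 3 to compound 4 (0.08 log units; within the scatter). Compound 4 is therefore estimated at 30 nM, within 12 nM to 75 nM.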

Compound 4, half-maximal inhibitory concentration: 14 nM
Compound 4: the middle estimate sits 2.1-fold (0.33 log units) above what was measured; low and high end bracket the measured number.
By their numbers in this assay, from the lowest: compounds 4, 3, 1 and 2 (each within the scatter of the next, the first and the last beyond it).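

Going by these compounds alone, at this position, ortho to a methylsulfonyl group, the exchange of cyclohexyl for 5-chloropyridin-3-yl on the oxygen gives the first step beyond the scatter in this assay (a 2.6-fold lower number from compound 2 to compound 4 (0.42 log units; beyond the scatter)), though only a modest one. The other two exchanges stay within the scatter (a 1.8-fold lower number from compound 3 to compound 4 (0.25 log units; within the scatter); a 2.0-fold lower number from compound 1 to compound 4 (0.30 log units; within the scatter)), so the new group is separated from cyclohexyloxy alone. No measurement on hand accounts for this step.

Open, as far as these compounds go, is what the chlorine contributes, which a plain pyridin-3-yl on the same oxygen would address. Also open, from the compounds shown here alone, is whether an amine such as piperidin-1-yl on this aromatic carbon falls within the same range.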